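Aryl swap at the core of compound 1

The source may hold more compounds than are shown below. What is called first, only, known or untested is meant among the compounds shown, and "the series" means these compounds.

Measured so far in a functional assay on DU-145 cells (Homo sapiens) for cytotoxicity, in the presence of a further agent that is not named here; on this read-out lower numbers stand for stronger inhibition and higher numbers for weaker inhibition:
- compound 1 `Clc1ccc(-c2cc(-c3ccsc3)nc(-c3ccco3)c2)o1` gives 18900 nM
- compound 2 `Clc1ccc(-c2cc(-c3ccoc3)cc(-c3cccs3)n2)cc1` gives 21100 nM
- compound 3 `Cc1ccc(-c2cc(-c3ccc(Cl)o3)cc(-c3cccs3)n2)cc1` gives 19300 nM

Compound 1 carries the lowest of the three numbers, but its neighbours lie within the usual scatter on both sides: compound 3 sits closest, compound 2 furthest, and neither gap is beyond what repeat runs of this assay produce. On the numbers shown, the three compounds cannot be told apart, and no ordering among them is claimed.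

The unmeasured compound 4 `Clc1cccc(-c2cc(-c3ccc(Cl)o3)cc(-c3ccsc3)n2)c1` differs from compound 1 in one place: 3-chlorophenyl in place of furan-2-yl on an aromatic carbon. The change puts a 3-chlorophenyl group on an aromatic carbon of the shared core in place of furan-2-yl, while the 5-chlorofuran-2-yl and thiophen-3-yl groups stay.

Within the data shown here, no step between two measured compounds is recorded, so the size of this change has not been seen directly. Compound 2, which carries a six-membered carbon ring at a comparable place, gives 21100 nM, and compound 3 gives 19300 nM; both lie within the scatter of compound 1. The expectation is therefore a step of a 1.1-fold higher number from compound 1 to compound 4 (0.02 log units; within the scatter) of no size beyond the scatter, in no firm direction. For compound 4 the estimated value in this assay is 20000 nM, with a range from 9000 nM to 45000 nM.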

Compound 4, half-maximal inhibitory concentration: 10400 nM
The estimate for compound 4 lay 1.9-fold (0.28 log units) above the measured number; the measured number falls inside the stated range.
By their numbers in this assay, from the lowest: compounds 4, 1, 3 and 2 (each within the scatter of the next, the first and the last beyond it).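

In this assay, among these compounds, the step at this position, 3-chlorophenyl in place of furan-2-yl on an aromatic carbon next to the ring nitrogen, reads as a 1.8-fold lower number from compound 1 to compound 4 (0.26 log units; within the scatter), the first direct reading of any single change. A five-membered aromatic ring with 1 hetero atom can therefore give way here to a six-membered aromatic ring of carbon only, with the hydrogen-bond acceptor counted on furan-2-yl gone, and the number stays within the scatter, so no direction is claimed for the swap. Nothing at hand explains this result.

Still open, going by these compounds, is whether the chlorine of the 3-chlorophenyl group matters at this place, a question that a plain phenyl group or a 3-methoxyphenyl group would put to the test against compound 4. Also open, on these data alone, is whether this position stays as permissive for groups of another kind, such as an aminomethyl group, a carboxylic acid or a longer alkyl chain, or whether one of these would produce a step beyond the scatter.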